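The source may hold more compounds than are shown below. What is called first, only, known or untested is meant among the compounds shown, and "the series" means these compounds.

Two compounds share one frame here: compound 1 `COc1cc(C(=O)/C=C/c2cn(C)c3ccccc23)cc(N)c1OC` and compound 2 `COc1cc(C(=O)/C(C)=C/c2c[nH]c3ccccc23)cc([Se]C)c1OC`. In a functional assay on A2780 cells (Homo sapiens) for antiproliferative activity, read by MTT assay, with a stated time of 48 h (a lower number here means a stronger inhibitor, a higher number a weaker inhibitor), compound 1 gives 441 nM, while in this assay compound 2 gives 25 nM. Compound 2 thus holds the lowest of the two numbers, and its gap to compound 1 lies well beyond the usual scatter of this kind of measurement, so compound 2 is the stronger inhibitor of the pair. The unmeasured compound 3 `COc1ccc2c(/C=C(\C)C(=O)c3cc(OC)c(OC)c([Se]C)c3)c[nH]c2c1` differs from compound 2 by a single change: methoxy in place of hydrogen on an aromatic carbon. Within the data shown here, no pair of measured compounds shows what this change does in this assay, so the expectation rests on compound 2 alone. For the step of a 1.4-fold higher number from compound 2 to compound 3 (0.15 log units; within the scatter) only a small shift is expected, within or just beyond the scatter, in either direction. For compound 3 in this assay the expected value is 35 nM, with a range from 10 nM to 120 nM.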

Compound 3, half-maximal inhibitory concentration: 18 nM
Estimate against measurement, compound 3: 1.9-fold (0.29 log units) above; the measured number falls inside the stated range.
By their numbers in this assay, from the lowest: compounds 3 and 2 (each within the scatter of the next); then compound 1.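

In this assay, methoxy in place of hydrogen gives a 1.4-fold lower number from compound 2 to compound 3 (0.14 log units; within the scatter), and since this step lies within the usual scatter, the two compounds cannot be told apart in this assay. Among these compounds, this is the first measured step at this position, an aromatic carbon of the six-membered ring of carbon only, and it shows that this ring carbon can carry a methoxy group while the antiproliferative activity stays in the same range as that of compound 2. A single step describes one group at one carbon, so it marks this position as open to methoxy and says nothing wider about substitution on the ring.

On these data alone, whether an amine, a chlorine atom or a longer ether chain such as butoxy would fit this carbon equally well stays open. Nothing measured here bears on this result.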